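The source may hold more compounds than are shown below. What is called first, only, known or untested is meant among the compounds shown, and "the series" means these compounds.

Two hydroxamic acids sharing one core have been measured in a functional assay on MDA-MB-231 cells (Homo sapiens) for inhibition, read by sulforhodamine B assay; on this read-out higher numbers stand for weaker inhibition of growth and lower numbers for stronger inhibition of growth. Compound 1 `Cc1ccc(CN2CC=C(CCC(=O)NO)C2=O)cc1` carries a methyl on its benzyl ring, and in this assay compound 1 gives 1990 nM. Compound 2 `N#Cc1cccc(CN2CC=C(CCC(=O)NO)C2=O)c1` carries a cyano on the same ring, and in this assay compound 2 gives 3600 nM. Going by the values given here, of the two numbers, the one for compound 1 is the lower, but the gap to compound 2 lies within the usual scatter of repeated measurements, so the two compounds cannot be told apart on this evidence.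

Compound 3 `N#Cc1ccc(CN2CC=C(CCC(=O)NO)C2=O)cc1` is the next member. It differs from compound 1 in a single way: cyano in place of methyl on an aromatic carbon. Among the compounds with values here, no pair of measured compounds separated by a single change is available, so there is no measured step to lean on.

The outcome for compound 3 is therefore expected to lie close to the values of both compound 1 and compound 2, with a step from compound 1 of a 1.4-fold higher number from compound 1 to compound 3 (0.15 log units; within the scatter) that stays within the scatter. The estimate for compound 3 in this assay is 2800 nM, with a range from 1000 nM to 7500 nM.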

Compound 3, concentration for 50% growth inhibition: 5380 nM
Beside the measured number, compound 3's estimate is 1.9-fold (0.28 log units) below it; low and high end bracket the measured number.
By their numbers in this assay, from the lowest: compounds 1, 2 and 3 (each within the scatter of the next, the first and the last beyond it).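

Going by these compounds alone, replacing methyl with cyano on the aromatic carbon para to a large group is the first single change here that can be read on its own, and in this assay it gives a 2.7-fold higher number from compound 1 to compound 3 (0.43 log units; beyond the scatter) as a modest step beyond the scatter. The group at this position therefore does make a measurable difference, with cyano giving weaker inhibition of growth than methyl, something the earlier comparison of compound 1 and compound 2 could not show with its gap inside the scatter. No measurement at hand bears on why this step occurs.

The compounds shown carry only methyl or cyano on the benzyl ring, so this one step says nothing about how an amine, a carboxylic acid or a chlorine atom on the same carbon would behave. It also leaves open whether the same swap would give a step of similar size if a longer chain carried the hydroxamic acid on the shared core.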